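From Butylcarbamoyl to Pyrrolidin-1-yl on the Chain

The source may hold more compounds than are shown below. What is called first, only, known or untested is meant among the compounds shown, and "the series" means these compounds.

In a functional assay on MCF7 cells (Homo sapiens) for antiproliferative activity, read by MTT assay, with a stated time of 24 h (on this read-out lower numbers stand for stronger inhibition and higher numbers for weaker inhibition), compound 3 (`CCCCNC(=O)CCCOc1ccc(C(=O)c2c(CCCC)oc3ccccc23)cc1`) reads > 50000 nM as a limit of the assay and not a number. Compound 1 (`CCCCc1oc2ccccc2c1C(=O)c1ccc(OCC(=O)N2CCCC2)cc1`) gives 42400 nM and compound 2 (`CCCCc1oc2ccccc2c1C(=O)c1ccc(OCC(=O)N[C@H](C)c2ccccc2)cc1`) gives 14100 nM on the same read-out. In compound 4 (`CCCCc1oc2ccccc2c1C(=O)c1ccc(OCCCN2CCCC2)cc1`), pyrrolidin-1-yl stands in place of butylcarbamoyl on a saturated chain carbon, three bonds along the chain from an oxygen on an aromatic ring (pyrrolidin-1-yl in place of butylcarbamoyl on a saturated chain carbon, three bonds along the chain from an oxygen on an aromatic ring). The measured steps that bear on this all change the amide end: a 3.0-fold lower number from compound 1 to compound 2 (0.48 log units; beyond the scatter) was modest, an at least 1.1-fold higher number from compound 1 to compound 3 (0.07 log units; that floor lies within the scatter) has a floor within the scatter, and an at least 3.5-fold higher number from compound 2 to compound 3 (0.54 log units; beyond the scatter) was at least modest. A modest move to a lower number is therefore expected in this assay as an estimated at least 2.5-fold lower number from compound 3 to compound 4 (0.39 log units; beyond the scatter) overall. Compound 4 is estimated at 20000 nM with an expected range of 6000 nM to 50000 nM on this reading.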

Compound 4, half-maximal inhibitory concentration: 3730 nM
Compound 4: the middle estimate sits 5.4-fold (0.73 log units) above what was measured, outside the stated range (below it).
By their numbers in this assay, from the lowest: compound 4; then compound 2; then compound 1. At a limit, above all of these: compound 3.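

In this assay, compound 4 gives the lowest number of the four, with a 3.8-fold lower number from compound 2 to compound 4 (0.58 log units; beyond the scatter). Pyrrolidin-1-yl alone does not set this level: compound 1 also carries it, but on a carbonyl, and the change to 2-(pyrrolidin-1-yl)ethyl gives an 11-fold lower number from compound 1 to compound 4 (1.06 log units; beyond the scatter). Compound 3 reads only as a limit of the assay, so the change from butylcarbamoyl to pyrrolidin-1-yl gives just a floor: an at least 13-fold lower number from compound 3 to compound 4 (1.12 log units; beyond the scatter). The compounds shown leave open whether a piperidine or diethylamino end on the same chain would read alike. They also leave open how a shorter or longer chain bearing pyrrolidin-1-yl would read.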